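Sulfonate Nucleosides: Swapping the Side Chain on Compound 2

A few compounds are considered here, and "the series" means these few. Any claim that something is new, unique, unknown or untested is made for them only; others in the source may bear on it.

The measured compounds so far:
compound 1, `Cc1cn([C@@H]2O[C@@H]3COC(=O)[C@]3(OS(C)(=O)=O)[C@H]2O)c(=O)[nH]c1=O`, 160000 nM
compound 2, `C=C(C)C(=O)NC(=O)NC1=CS(=O)(=O)O[C@@]12[C@@H](CO[Si](C)(C)C(C)(C)C)O[C@@H](n1cc(C)c(=O)n(C)c1=O)[C@@H]2O[Si](C)(C)C(C)(C)C`, 1200 nM
compound 3, `Cc1cn([C@@H]2O[C@@H]3COC4(O)CS(=O)(=O)O[C@@]34[C@H]2O)c(=O)[nH]c1=O`, 100000 nM

All three were tested in a functional assay on CCRF-CEM cells (Homo sapiens); a higher number here means that more compound is tolerated, a lower number that less compound is tolerated. Compound 2 stands at the low end of the three numbers: its value of 1200 nM lies well beyond the scatter from that of compound 3, which gives 100000 nM, and further still from compound 1, which gives 160000 nM. Compound 2 is therefore the compound of which the cells tolerate the least.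

Compound 4, `Cc1cn([C@@H]2O[C@H](CO[Si](C)(C)C(C)(C)C)[C@@]3(OS(=O)(=O)C=C3NCCC(=O)OCc3ccccc3)[C@H]2O[Si](C)(C)C(C)(C)C)c(=O)n(C)c1=O`, has not been measured. It keeps the core of compound 2 with its silyl groups and the methylated base and differs in one place: 2-(benzyloxycarbonyl)ethyl in place of ((1-methylethenyl)carbonyl)carbamoyl on an amine nitrogen.

Going by the values given here, no pair of measured compounds differs by a single change, so there is no directly comparable step to lean on. The core that carries the low number of compound 2 is kept, and only the side chain on the amine nitrogen is exchanged. The step of a 2.5-fold higher number from compound 2 to compound 4 (0.40 log units; beyond the scatter) is expected to be modest, leaning towards a somewhat higher number, though a result within the scatter would not surprise. Compound 4 is estimated at 3000 nM, with a plausible range from 800 nM to 15000 nM.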

Compound 4, half-maximal cytotoxic concentration: > 250000 nM
Compound 4: only a limit was reported (the forecaster's own chance of this, stated with the estimate: 10%); middle value at least 83-fold (1.92 log units) from the limit.
By their numbers in this assay, from the lowest: compound 2; then compounds 3 and 1 (each within the scatter of the next). At a limit, above all of these: compound 4.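

In this assay, putting 2-(benzyloxycarbonyl)ethyl in place of ((1-methylethenyl)carbonyl)carbamoyl on the amine nitrogen gives an at least 200-fold higher number from compound 2 to compound 4 (2.31 log units; beyond the scatter), a large step for a change in one place. The value of compound 4, > 250000 nM, is a limit and not a number: the limit of > 250000 nM in this assay, at which 1 of the 4 values shown sits. Going by these compounds alone, compound 4 keeps the silyl groups, the methylated base and the core of compound 2, so these parts alone do not carry the low number of compound 2, and what sits on this nitrogen clearly matters, which the earlier compounds could not show, as no two of them differ in one place.

From the compounds shown here alone, a whole side chain was exchanged in this step, so it remains open which part of ((1-methylethenyl)carbonyl)carbamoyl the low number of compound 2 depends on, or whether the entering 2-(benzyloxycarbonyl)ethyl accounts for much of the step. An acetylcarbamoyl group, which lacks the carbon-carbon double bond, would help to separate these possibilities, as would a free amine at this nitrogen or a carboxylic acid in place of the benzyl ester.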